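The source may hold more compounds than are shown below. What is called first, only, known or untested is meant among the compounds shown, and "the series" means these compounds.

Working notes on the arylthiomethyl series.

Of the compounds shown here, two carry numbers so far. Compound 1 `Cc1cc(C)c(SCc2ncnc3c2ncn3[C@@H]2O[C@H](CO)[C@@H](O)[C@H]2O)c(C)c1` bears 2,4,6-trimethylphenyl on the sulfur, compound 2 `COC(=O)c1ccc(SCc2ncnc3c2ncn3[C@@H]2O[C@H](CO)[C@@H](O)[C@H]2O)cc1` bears 4-(methoxycarbonyl)phenyl there. In an assay on isolated protein for binding affinity to Equilibrative nucleoside transporter 1 (Homo sapiens) (a higher number here means a weaker inhibitor, a lower number a stronger inhibitor), compound 1 gives 33100 nM. In this assay, among the measured compounds shown here, compound 2 gives 813 nM, the lowest of the two numbers; the only measured step, a 41-fold lower number from compound 1 to compound 2 (1.61 log units; beyond the scatter), shows that the aryl substituent on the sulfur moves the read-out strongly.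

Compound 3 `OC[C@H]1O[C@@H](n2cnc3c(CSc4ccc(F)cc4)ncnc32)[C@H](O)[C@@H]1O` is the next member. Relative to compound 2 the change is fluoro in place of methoxycarbonyl on an aromatic carbon. For the measured compounds named here, no measured step covers this exact exchange; the one measured step, a 41-fold lower number from compound 1 to compound 2 (1.61 log units; beyond the scatter), compares a trimethyl pattern with the ester and says nothing directly about a single fluorine. Given that compound 2 holds the better value, 813 nM, and that the group which leaves is what distinguished it from compound 1, a move back toward a higher number is the expectation, though not of the full size seen between compounds 1 and 2. The estimated step is a 3.1-fold higher number from compound 2 to compound 3 (0.49 log units; beyond the scatter). Compound 3 is expected to give about 2500 nM, within 600 nM to 10000 nM.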

Compound 3, half-maximal inhibitory concentration: 158 nM
Estimate against measurement, compound 3: 16-fold (1.20 log units) above; measured number outside the range, below it.
By their numbers in this assay, from the lowest: compound 3; then compound 2; then compound 1.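

Methoxycarbonyl is not needed for the lower number in this assay: fluoro on the same aromatic carbon gives a 5.1-fold lower number from compound 2 to compound 3 (0.71 log units; beyond the scatter) even though only one heavy atom remains there, in place of four, and no hydrogen-bond acceptor is counted. Measured from the 2,4,6-trimethylphenyl compound, the 4-fluorophenyl group gives a 210-fold lower number from compound 1 to compound 3 (2.32 log units; beyond the scatter) and so exceeds the earlier 41-fold lower number from compound 1 to compound 2 (1.61 log units; beyond the scatter) within this set of three, which means the ester did not mark the upper end of what the aryl group on the sulfur can do. The numbers alone give no account of why the smaller group does better, and nothing measured alongside them bears on that.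

From the compounds shown here alone, whether fluoro itself contributes remains open, since a plain phenyl group with hydrogen on that carbon would be needed to separate the effect of adding fluoro from that of removing the ester, and chloro, nitrile or an amine on the same carbon would show how far the trend extends. Going by these compounds, it is also open how much of the high number of compound 1 comes from its methyl at the far end of the ring and how much from the other two methyl groups.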